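Toxicity Outlook for an Unmeasured Analogue

The source may report more compounds than this note shows. Statements on the series, on what has been measured and on what is new or still open speak of the compounds shown alone.

Compound 1 `COc1cccc(NC(=O)c2nnn(Cc3cc(C)on3)c2N)c1`: > 50100 nM in a toxicity assay on Vero cells (Chlorocebus sabaeus) for inhibition (on this read-out lower numbers stand for an effect already at smaller amounts and higher numbers for an effect only at larger amounts of compound), a limit.
Compound 2 `COc1cccc(NC(=O)c2nnn(Cc3ccc(-n4cccn4)cc3)c2N)c1`: > 50100 nM, a limit.
Compound 3 `COc1cccc(NC(=O)c2nnn(Cc3ccncc3)c2N)c1`: > 50100 nM, a limit.

Compound 3 stands at the limit of this assay, and the other two compounds stand there too; the limit of > 50100 nM in this assay, at which 3 of the 3 values shown sit, is all the evidence available. Going by the values given here, the only single-point step, a step that the two limits leave unreadable from compound 1 to compound 3, has no readable size. Compound 4 `COc1cccc(NC(=O)c2nnn(Cc3ccc([S+](C)[O-])cc3)c2N)c1` differs from compound 3 by a group of 9 heavy atoms (7 carbon, 1 oxygen, 1 sulfur; one six-membered aromatic ring of carbon only) in place of a group of 6 heavy atoms (5 carbon, 1 nitrogen; one six-membered aromatic ring with 1 hetero atom), on a saturated chain carbon bound to an aromatic nitrogen. Among the compounds with values here, no measured step reads on this change, so no shift beyond the scatter is expected in this assay, and the expected step is a number no higher from compound 3 to compound 4 (the limit leaves the size open). Compound 4 is therefore estimated at 50100 nM, within 25000 nM to 100000 nM, and is most likely to be reported again only as a limit.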

Compound 4, half-maximal effective concentration in the Vero assay: > 50100 nM
Compound 4 was reported as a limit (the forecaster's own chance of this, stated with the estimate: 85%); the middle value sits exactly at the limit.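

In the Vero assay, compound 4 sits at the same limit as compound 1, compound 2 and compound 3, so none of its steps from them can be read. In a physicochemical assay for solubility, read by nephelometry, at pH 7.4 (on this read-out higher numbers stand for higher solubility and lower numbers for lower solubility), compound 3 gives < 12000 nM, which is a limit. In the physicochemical assay compound 4 gives > 250000 nM, which is also a limit. The compounds shown leave open at what concentration, if any, compound 1, compound 2, compound 3 or compound 4 would show an effect in the Vero assay.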